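This account rests on a few compounds, and the source may have more. Where it says the series, first, only, none or still open, it means among the compounds named here.

Measured compounds:
compound 1 `COc1ccc2[nH]cc(C(=O)/C(C#N)=C/C=C(\Cl)c3ccc(Br)cc3)c2c1`, 40.8% in a functional assay for inhibition, with a stated time of 30 min, tested at 1 mM; on this read-out higher numbers stand for more inhibition at the one concentration tested (going by the name of the read-out) and lower numbers for less inhibition
compound 2 `N#C/C(=C\C=C(/Cl)c1ccc(Br)cc1)C(=O)c1c[nH]c2ccccc12`, 18.4%
compound 3 `COc1ccc(/C(Cl)=C/C=C(\C#N)C(=O)c2c[nH]c3ccccc23)cc1`, 23.4%

Compound 4 `COc1ccc(/C(Cl)=C/C=C(\C#N)C(=O)c2c[nH]c3ccccc23)cc1OC` is not yet measured. Compound 4 differs from compound 3 by methoxy in place of hydrogen on an aromatic carbon. The same kind of change separates compound 2 from compound 1, (methoxy in place of hydrogen on an aromatic carbon), where it gave a number 22.4 percentage points higher from compound 2 to compound 1 (beyond the scatter). The places differ: in compound 1 the methoxy sits on a ring that is part of a fused system of two rings, meta and para to a fused ring; in compound 4 it sits on a six-membered ring of carbon only, ortho to a methoxy group and meta to a large group. The two cores differ by methoxy in place of bromo on an aromatic carbon, a step of a number 5 percentage points higher from compound 2 to compound 3 (within the scatter).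

Given the different place, a smaller step than the earlier one is expected, a number 7.6 percentage points higher from compound 3 to compound 4 (within the scatter). Compound 4 is estimated at 31%, between 15% and 48%.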

Compound 4, a percentage reported as inhibition, at one concentration (the size of the read-out at that concentration, not a potency): 15.8%
The estimate for compound 4 lay 15.2 percentage points above the measured number; the measured number falls inside the stated range.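

Methoxy in place of hydrogen on an aromatic carbon gives, in this assay, a number 7.6 percentage points lower from compound 3 to compound 4 (within the scatter), so the gain seen on the core of compound 2 does not carry over to the core of compound 3: the same change on two cores in this assay, a number 22.4 percentage points higher (beyond the scatter) from compound 2 to compound 1 and a number 7.6 percentage points lower (within the scatter) from compound 3 to compound 4, 30 percentage points apart, beyond the scatter of two such steps. A step measured on one of these cores is therefore no safe guide to the other. For the compounds shown here, this does not show that the core alone decides the outcome, since the methoxy also sits in a different place in each pair and each core offers only one pair.

The compounds shown leave open whether methoxy placed as in compound 1 would give a higher number on the core of compound 3. Also open, going by these compounds, is how an amine or a carboxylic acid would read on the six-membered aromatic ring of compound 3.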